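Mirror image of compound 3 in the bicyclic ether series

A few compounds are considered here, and "the series" means these few. Any claim that something is new, unique, unknown or untested is made for them only; others in the source may bear on it.

The three measured compounds of this series are compound 1 `OC(c1ccccn1)C1(c2ccc(Cl)c(Cl)c2)CCOC1`, compound 2 `O[C@H](c1ccccn1)C1(c2ccc(OC(F)(F)F)cc2)CC(F)(F)C1` and compound 3 `C[C@]1(c2ccc(OC(F)(F)F)cc2)C[C@@](O)(c2ccccn2)CO1`. In an assay on HEK293 cells for antagonist activity at transient receptor potential cation channel subfamily V member 3 (Homo sapiens), read by FLIPR and calcium flux (a lower number here means a stronger inhibitor, a higher number a weaker inhibitor), compound 1 gives 630 nM. In this assay compound 2 gives 40 nM. In this assay compound 3 gives 2460 nM, the highest number of the three, beyond the scatter from both compound 1 and compound 2, so compound 3 is the weakest inhibitor measured so far.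

Compound 4 `C[C@@]1(c2ccc(OC(F)(F)F)cc2)C[C@](O)(c2ccccn2)CO1` is the mirror image of compound 3: the two compounds have the same atoms and bonds and differ only in configuration as drawn: 2 of 2 stereo elements differ (all stereocentres are inverted: mirror images); a stereocentre at a saturated ring carbon is drawn R in compound 3 and S in compound 4; a stereocentre at a saturated ring carbon is drawn R in compound 3 and S in compound 4. Among the compounds with values here, no measured pair of this kind stands in the data, so no step between stereoisomers is known here. Since compound 3 gives 2460 nM and a single configuration such as compound 2 gives 40 nM, the inverted configuration is expected to matter, and the number is expected to move lower, beyond the scatter, though with wide uncertainty. The expected step of a 4.9-fold lower number from compound 3 to compound 4 (0.69 log units; beyond the scatter) is therefore toward stronger inhibition. Compound 4 is expected to give 500 nM, with a range from 80 nM to 3000 nM.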

Compound 4, antagonist equilibrium constant: 1710 nM
Estimate against measurement, compound 4: 3.4-fold (0.53 log units) below; low and high end bracket the measured number.
By their numbers in this assay, from the lowest: compound 2; then compound 1; then compounds 4 and 3 (each within the scatter of the next).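

In this assay, within the data shown here, inverting both stereocentres gives a 1.4-fold lower number from compound 3 to compound 4 (0.16 log units; within the scatter), the first step that reads configuration on its own. The comparison carries no change of group and rests on a single fact: the fact that compounds 3 and 4 differ only in the configuration as drawn. Within this pair, full inversion therefore does not separate the two mirror images in this assay, and neither compound can be ranked above the other.

The compounds shown leave open how a form with only one of the two stereocentres inverted would read, since both centres change together in this pair. They also leave open whether an amine in place of the hydroxyl group, or an ethyl group in place of the methyl group, would move the number in either configuration.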